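Stretching the amine-bearing chain on a cinnamanilide core

The source may hold more compounds than are shown below. What is called first, only, known or untested is meant among the compounds shown, and "the series" means these compounds.

Measured compounds:
compound 1 `COc1cc(/C=C/C(=O)Nc2ccccc2)ccc1OCCCN1CCCCC1` gives 1.58
compound 2 `COc1cc(/C=C/C(=O)Nc2ccccc2)ccc1OCCCCN1CCCC1` gives 1.6
compound 3 `COc1cc(/C=C/C(=O)Nc2ccccc2)ccc1OCCCCCN(C)C` gives 1.61

These three share a core and differ only in the chain that carries a basic amine. In a physicochemical assay for lipophilicity, using the shake flask method, measured as octanol-water partition, at pH 7.4 (a lower number here means a more polar compound, a higher number a more lipophilic compound), compound 3 sits highest of the three numbers, but its nearest neighbour, compound 2, lies lower by a number 0.01 log units higher from compound 2 to compound 3 (within the scatter), and compound 1 by a number 0.03 log units higher from compound 1 to compound 3 (within the scatter); both gaps are within the scatter, so the three compounds cannot be told apart on this measurement.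

Compound 4 `COc1cc(/C=C/C(=O)Nc2ccccc2)ccc1OCCCCCCCCCCN1CCCCC1` is the next step. The change from compound 3 is 5-(piperidin-1-yl)pentyl in place of dimethylamino on a saturated chain carbon, five bonds along the chain from an oxygen on an aromatic ring. In words, it leaves a small amine group and enters a far longer chain ending in a six-membered ring.

The measured steps bear only loosely on this. Steps a number 0.02 log units higher from compound 1 to compound 2 (within the scatter) and a number 0.03 log units higher from compound 1 to compound 3 (within the scatter) swapped one amine-bearing chain for another of similar build, and neither moved the number beyond the scatter. The change to compound 4 is of a different kind, adding many carbon atoms, so a step in this assay well beyond the scatter is expected, in the upward, more lipophilic direction.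

Compound 4 is therefore expected to read 4, within the range 3 to 5, a rise of a number 2.39 log units higher from compound 3 to compound 4 (beyond the scatter).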

Compound 4, partition coefficient: 1.83
The estimate for compound 4 lay 2.17 log units above the measured number, and the stated range ends above it.
By their numbers in this assay, from the lowest: compounds 1, 2, 3 and 4 (each within the scatter of the next).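

Measured by this assay the swap of dimethylamino for 5-(piperidin-1-yl)pentyl, on a saturated chain carbon five bonds along the chain from an oxygen on an aromatic ring, gives a number 0.22 log units higher from compound 3 to compound 4 (within the scatter) and the swap of pyrrolidin-1-yl for 6-(piperidin-1-yl)hexyl, four bonds along the chain from that oxygen, gives a number 0.23 log units higher from compound 2 to compound 4 (within the scatter) even though both entering groups are far larger than those they replace. The earlier steps shown here only exchanged amine-bearing chains of similar build, whereas here 11 heavy atoms enter where 3 leave, and compound 4 still cannot be told apart from compound 3 or compound 2 on this measurement. No measurement at hand accounts for so large an addition staying within the scatter.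

As far as these compounds go, whether a still longer chain would step beyond the scatter in this assay remains open. Also open, from the compounds shown here alone, is what happens when the same long chain ends in a morpholine ring or a carboxylic acid instead of the piperidine ring of compound 4.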